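Acyl exchange on a tetrahydroquinoline carboxamide series

The compounds below may be only part of what the source reports. "The series", "measured", "known", "first", "only" and "open" are said of these compounds alone.

Measured compounds:
compound 1 `CC(=O)N1c2ccccc2CCC1C(=O)Nc1ccccc1O` — 50700 nM
compound 2 `O=C(Nc1ccccc1O)C1CCc2ccccc2N1C(=O)c1ccc(Cl)cc1` — 19600 nM
compound 3 `O=C(Nc1ccccc1C(F)(F)F)C1CCc2ccccc2N1C(=O)c1ccc(Cl)cc1` — 824 nM

Of the compounds shown here, three have been tested in a functional assay on ACHN cells (Homo sapiens) for cytotoxicity, read by sulforhodamine B assay, with a stated time of 72 h; on this read-out higher numbers stand for weaker inhibition of growth and lower numbers for stronger inhibition of growth. Compound 3 gives the lowest number of the three, and the step between compound 2 and compound 3 is a 24-fold lower number from compound 2 to compound 3 (1.38 log units; beyond the scatter); the two differ by trifluoromethyl in place of hydroxy on an aromatic carbon. Compound 1 relates to compound 2 through (methyl in place of 4-chlorophenyl on a carbonyl carbon), and that change gave a 2.6-fold higher number from compound 2 to compound 1 (0.41 log units; beyond the scatter).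

Compound 4 `CC(=O)N1c2ccccc2CCC1C(=O)Nc1ccccc1C(F)(F)F` has not yet been measured. It relates to compound 3 through (methyl in place of 4-chlorophenyl on a carbonyl carbon), the same change that was made from compound 2 to compound 1, at a place described in the same words in both pairs. The cores of the two pairs differ by trifluoromethyl in place of hydroxy on an aromatic carbon. Because the earlier change gave a 2.6-fold higher number from compound 2 to compound 1 (0.41 log units; beyond the scatter), a step of similar size is expected here, namely a 2.5-fold higher number from compound 3 to compound 4 (0.41 log units; beyond the scatter) from compound 3 to compound 4. On that basis compound 4 is estimated at 2100 nM in this assay. The expected range for compound 4 is 900 nM to 6000 nM.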

Compound 4, concentration for 50% growth inhibition: > 80000 nM
Compound 4: a limit, no number (the forecaster's own chance of this, stated with the estimate: 5%); middle value at least 38-fold (1.58 log units) away from the limit.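

In this assay compound 4 gives > 80000 nM, which is a limit of the assay and not a number. Methyl in place of 4-chlorophenyl on the carbonyl carbon gave an at least 97-fold higher number from compound 3 to compound 4 (1.98 log units; beyond the scatter), so although the change moves the number upward on both cores, its size did not carry over from the core with hydroxy to the core with trifluoromethyl: the same change on two cores in this assay, a 2.6-fold higher number (0.41 log units; beyond the scatter) from compound 2 to compound 1 and an at least 97-fold higher number (1.98 log units; beyond the scatter) from compound 3 to compound 4, at least 37-fold (1.57 log units) apart, beyond the scatter of two such steps Trifluoromethyl in place of hydroxy gave an at least 1.5-fold higher number from compound 1 to compound 4 (0.19 log units; that floor lies within the scatter) with the acetyl group, unlike the lower number it gave with the (4-chlorophenyl)carbonyl group, but the full size of this step is not shown, and these two pairs of compounds set no rule for the wider series: the same change on two cores in this assay, a 24-fold lower number (1.38 log units; beyond the scatter) from compound 2 to compound 3 and an at least 1.5-fold higher number (0.19 log units; that floor lies within the scatter) from compound 1 to compound 4, at least 37-fold (1.57 log units) apart, beyond the scatter of two such steps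

As far as these compounds go, it remains open whether a longer chain or an unsubstituted phenyl on the carbonyl carbon would behave more like methyl or like 4-chlorophenyl. From the compounds shown here alone, it is also open how an amine or a carboxylic acid in place of trifluoromethyl on the aromatic carbon would respond to the same exchange.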